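From pyrrolidin-2-yl to pyridin-3-yl on compound 2

The source may hold more compounds than are shown below. What is called first, only, known or untested is meant among the compounds shown, and "the series" means these compounds.

Values measured in a functional assay on MIA PaCa-2 cells (Homo sapiens) for antiproliferative activity, read by MTT assay, with a stated time of 24 h (on this read-out higher numbers stand for weaker inhibition and lower numbers for stronger inhibition), are these:
Compound 1 `c1ccc(-c2noc(-c3ccncc3)n2)cc1` gives 497000 nM
Compound 2 `COc1ccc(-c2noc(C3CCCN3)n2)cc1OC1CCCC1` gives 19500 nM
Compound 3 `Fc1ccc(-c2nc(-c3ccccc3)no2)cc1` gives > 1000000 nM as a limit of the assay, not a number

Compound 2 holds the lower of the two true numbers, and compound 1 stands above it by more than the scatter of repeated measurements. Compound 4 `COc1ccc(-c2noc(-c3cccnc3)n2)cc1OC1CCCC1` keeps the rest of compound 2 but carries pyridin-3-yl in place of pyrrolidin-2-yl on an aromatic carbon. Going by the values given here, no measured pair differs in only one place, so any forecast rests on little. Compound 1 has a six-membered aromatic ring with 1 hetero atom at the same place and gives 497000 nM in this assay but differs elsewhere too. In this assay the step of a 2.3-fold higher number from compound 2 to compound 4 (0.36 log units; beyond the scatter) is expected to be modest and towards weaker inhibition. Compound 4 is estimated at 45000 nM (expected range 10000 nM to 200000 nM).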

Compound 4, half-maximal inhibitory concentration: > 1000000 nM
Compound 4 was reported as a limit (the forecaster's own chance of this, stated with the estimate: 8%); middle value at least 22-fold (1.34 log units) away from the limit.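

In this assay, the place on the five-membered aromatic ring with 2 nitrogen and 1 oxygen proves sensitive: pyridin-3-yl in place of pyrrolidin-2-yl gives an at least 51-fold higher number from compound 2 to compound 4 (1.70 log units; beyond the scatter) with the rest of the molecule unchanged. Going by these compounds alone, this is the first pair here that differs in one place, so this change alone, rather than differences elsewhere in the molecule, accounts for the large loss of inhibition. The reading for compound 4 is a limit of the assay and not a number, so the step has a known minimum but no known full size: the limit of > 1000000 nM in this assay, at which 2 of the 4 values shown sit.

This change swaps a non-aromatic ring for an aromatic one, alters the ring size and removes a hydrogen-bond donor all at once, and the compounds shown do not separate these differences. As far as these compounds go, it remains open how a piperidin-3-yl ring or an open-chain amine such as aminomethyl would behave at this place.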